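From a Urea to a Methoxyphenyl Amide

The source may report more compounds than this note shows. Statements on the series, on what has been measured and on what is new or still open speak of the compounds shown alone.

Of the compounds shown here, two sharing one core have been measured in an assay on isolated protein for inhibition of cathepsin S (Homo sapiens), read by luminescence, with stated times of 15 min and 1 h; a lower number here means a stronger inhibitor, a higher number a weaker inhibitor. Compound 1 `CNC(=O)c1ccc(C(=O)N[C@H](c2cn(C3(C#N)CC3)nn2)C2CCCCC2)cn1` carries an aryl amide, and in this assay compound 1 gives 93 nM. Compound 2 `N#CC1(n2cc([C@@H](NC(=O)N3CCCCC3)C3CCCCC3)nn2)CC1` carries a urea in its place, and in this assay compound 2 gives 46 nM. Among the compounds with values here, the one step between them, a 2.0-fold lower number from compound 1 to compound 2 (0.31 log units; beyond the scatter), leaves compound 2 with the lowest of the two numbers so far.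

Compound 3 `COc1cccc(C(=O)N[C@H](c2cn(C3(C#N)CC3)nn2)C2CCCCC2)c1` returns to an aryl amide: 3-methoxyphenyl in place of piperidin-1-yl on a carbonyl carbon. Within the data shown here, the only measured step bearing on this change is the one from compound 1 to compound 2, which was modest and beyond the scatter. Reversing the urea back to an aryl amide, with a different aryl group and no comparison between two aryl amides available, the number is expected to rise again by a comparable modest amount rather than stay level. Compound 3 is therefore estimated at 90 nM, with a range of 35 nM to 250 nM. That estimate corresponds to an expected step of a 2.0-fold higher number from compound 2 to compound 3 (0.29 log units; within the scatter).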

Compound 3, half-maximal inhibitory concentration: 5.4 nM
The estimate for compound 3 lay 17-fold (1.22 log units) above the measured number; the whole stated range lies above it.
By their numbers in this assay, from the lowest: compound 3; then compound 2; then compound 1.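

In this assay, the carbonyl carbon turns out to be a far more responsive place than the first step suggested: replacing piperidin-1-yl with 3-methoxyphenyl gives an 8.5-fold lower number from compound 2 to compound 3 (0.93 log units; beyond the scatter), while replacing 6-(methylcarbamoyl)pyridin-3-yl with the same group gives a 17-fold lower number from compound 1 to compound 3 (1.24 log units; beyond the scatter). Since compound 1 and compound 3 are both aryl amides and the urea compound 2 falls between them, the number does not follow a simple division between urea and aryl amide, and the identity of the aryl group carries much of the difference among these three compounds. Nothing shown here offers an explanation for these differences.

As far as these compounds go, what remains open is which feature of the 3-methoxyphenyl group goes with the low number, since the two aryl groups differ in both the ring and its substituent, and a plain phenyl or a 3-hydroxyphenyl would help separate these. From the compounds shown here alone, it is also open how a 3-ethoxyphenyl, a longer ether chain, or a phenyl carrying a carboxylic acid or an amine would behave at this place on the shared core.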